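The source may report more compounds than this note shows. Statements on the series, on what has been measured and on what is new or still open speak of the compounds shown alone.

Working notes on the series. Within the data shown here, compound 1 `CCCCC/C=C\C/C=C\CCCCCCCc1cc(OC(C)=O)cc(OC(C)=O)c1` and compound 2 `CC/C=C\C[C@H](CC/C=C\CCCCCCCc1cc(OC(C)=O)cc(OC(C)=O)c1)OC(C)=O` are the two compounds measured so far. In an ADME assay on Vero cells (Homo sapiens) for cytotoxicity against Vero (Chlorocebus sabaeus), read by MTT assay (on this read-out higher numbers stand for weaker inhibition and lower numbers for stronger inhibition), compound 1 gives 124000 nM, and in this assay compound 2 gives 82000 nM. Among the measured compounds shown here, the only step between them, a 1.5-fold lower number from compound 1 to compound 2 (0.18 log units; within the scatter), is within the scatter, so compound 2 stands no further from compound 1 than repeated measurements would place it; the two numbers cannot be told apart.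

Compound 3 `CCCCCC[C@@H](C/C=C\CCCCCCCc1cc(OC(C)=O)cc(OC(C)=O)c1)OC(C)=O` is not yet measured. Its difference from compound 2 is a group of 11 heavy atoms (9 carbon, 2 oxygen; no ring) in place of a group of 11 heavy atoms (9 carbon, 2 oxygen; no ring), on a saturated chain carbon bound to a double-bonded chain carbon. For the measured compounds named here, the one measured step that bears on this region of the chain, a 1.5-fold lower number from compound 1 to compound 2 (0.18 log units; within the scatter), changed a group on the same saturated chain carbon and stayed within the scatter. The change from compound 2 to compound 3 keeps the atom count, the acceptors and the stereocentre and only removes one double bond outside aromatic rings, so no step beyond the scatter is expected in this assay; the expected step is a 1.1-fold higher number from compound 2 to compound 3 (0.04 log units; within the scatter). On that basis compound 3 is estimated to give 90000 nM in this assay, with an expected range from 40000 nM to 200000 nM.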

Compound 3, half-maximal inhibitory concentration: 75000 nM
Beside the measured number, compound 3's estimate is 1.2-fold (0.08 log units) above it; measured number inside the range.
By their numbers in this assay, from the lowest: compounds 3, 2 and 1 (each within the scatter of the next).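

In this assay the step of a 1.1-fold lower number from compound 2 to compound 3 (0.04 log units; within the scatter) shows that going from 2 double bonds outside aromatic rings to 1 in the group of 11 heavy atoms, on a saturated chain carbon bound to a double-bonded chain carbon, leaves the number within the scatter. The step of a 1.7-fold lower number from compound 1 to compound 3 (0.22 log units; within the scatter) adds a second group of 11 heavy atoms in place of the group of 7 heavy atoms, and it too stays within the scatter, so at this place two different groups of that size now read the same as the group of 7 heavy atoms and as each other. No supporting measurement is available that could explain this flat reading.

As far as these compounds go, compounds 1, 2 and 3 all lie within the scatter of one another, so it remains open whether any change at this place can move the number beyond the scatter. From the compounds shown here alone, how an amine, a carboxylic acid or a much shorter chain would read here stays open, as does the opposite configuration at the defined stereocentre.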